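Oxime-bearing hydroxamic acids: chloro substitution on the fused ring

A few compounds are considered here, and "the series" means these few. Any claim that something is new, unique, unknown or untested is made for them only; others in the source may bear on it.

Measured compounds:
compound 1, `O=C(CCCCCCN1C(=O)/C(=N\O)c2ccccc21)NO`: 640 nM
compound 2, `O=C(CCCCCCN1C(=O)/C(=N\O)c2cc(Cl)ccc21)NO`: 650 nM
compound 3, `CO/N=C1/C(=O)N(CCCCCCC(=O)NO)c2ccccc21`: 730 nM

Compound 1 and compound 2 share one core; compound 3 carries a different core, and the difference between the two cores is not broken down here. In a functional assay on SW-620 cells (Homo sapiens) for antiproliferative activity, read by sulforhodamine B assay, with a stated time of 48 h (a higher number here means a weaker inhibitor, a lower number a stronger inhibitor), compound 1 gives 640 nM, compound 2 gives 650 nM and compound 3 gives 730 nM; all three sit within the usual scatter of one another.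

Compound 2 arises from compound 1 by chloro in place of hydrogen on an aromatic carbon, and that step is a 1.0-fold higher number from compound 1 to compound 2 (0.01 log units; within the scatter).

Compound 4, `CO/N=C1/C(=O)N(CCCCCCC(=O)NO)c2c(Cl)cccc21`, is not yet measured. It arises from compound 3 by chloro in place of hydrogen on an aromatic carbon. This is the same kind of change, though the place differs: in compound 2 the chloro stands meta to a fused ring and para to a fused ring, in compound 4 ortho to a fused ring and meta to a fused ring. Since the earlier step was a 1.0-fold higher number from compound 1 to compound 2 (0.01 log units; within the scatter), the expected step in this assay is a 1.0-fold higher number from compound 3 to compound 4 (0.02 log units; within the scatter), within the scatter. Compound 4 is thus estimated at 760 nM, with a range from 400 nM to 1500 nM.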

Compound 4, half-maximal inhibitory concentration: 260 nM
Compound 4: middle estimate off by 2.9-fold (0.47 log units), on the high side, outside the stated range (below it).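

In this assay, chloro in place of hydrogen on an aromatic carbon gives a 2.8-fold lower number from compound 3 to compound 4 (0.45 log units; beyond the scatter). The change therefore does not carry over with the same size between the two cores: the same change on two cores in this assay, a 1.0-fold higher number (0.01 log units; within the scatter) from compound 1 to compound 2 and a 2.8-fold lower number (0.45 log units; beyond the scatter) from compound 3 to compound 4, 2.9-fold (0.46 log units) apart, beyond the scatter of two such steps

The two steps differ in the core and also in the place of the chloro, which in compound 4 is ortho to a fused ring and meta to a fused ring, so these compounds do not show which of the two differences goes with the gap, and one step on each core sets no rule for the series.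

Open, from the compounds shown here alone, is how chloro behaves at the place it holds in compound 4 on the core of compound 1, and at the place it holds in compound 2 on the core of compound 3. Also open, going by these compounds, is whether bromo or fluoro at the place it holds in compound 4 would follow chloro.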